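An Iodo Substituent Tested Against the Unsubstituted Parent

The source may hold more compounds than are shown below. What is called first, only, known or untested is meant among the compounds shown, and "the series" means these compounds.

Of the compounds shown here, three sharing a common core have been measured in a functional assay on COLO 205 cells (Homo sapiens) for inhibition, read by sulforhodamine B assay, with a stated time of 48 h, tested at 50 uM; a lower number here means less inhibition of growth, a higher number more inhibition of growth at the concentration tested. Compound 1 `O=C1C(=O)N(CCCCn2cc(COc3cc(=O)oc4ccccc34)nn2)c2ccc([N+](=O)[O-])cc21` carries a nitro group and gives 45%. Compound 2 `COc1ccc2c(c1)C(=O)C(=O)N2CCCCn1cc(COc2cc(=O)oc3ccccc23)nn1`, with a methoxy group on the same aromatic carbon, gives 41%, and compound 3 `O=C1C(=O)N(CCCCn2cc(COc3cc(=O)oc4ccccc34)nn2)c2ccccc21`, which has only hydrogen there, gives 68%. Compound 3 therefore stands highest of the three; its nearest neighbour is compound 1 and its furthest is compound 2.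

Compound 4 `O=C1C(=O)N(CCCCn2cc(COc3cc(=O)oc4ccccc34)nn2)c2ccc(I)cc21` differs from compound 3 by iodo in place of hydrogen on an aromatic carbon. Going by the values given here, two measured steps bear on this change, both replacing a substituent on that carbon with hydrogen: a number 23 percentage points higher from compound 1 to compound 3 (beyond the scatter) and a number 27 percentage points higher from compound 2 to compound 3 (beyond the scatter). In each case the unsubstituted compound 3 inhibited growth more than the substituted analogue, while the nitro and methoxy compounds gave values within the scatter of each other. Iodo is a third substituent on the same aromatic carbon, so a modest drop from compound 3 is expected, although no halogen has been measured in this series and the direction rests on only two steps. The estimated step is a number 18 percentage points lower from compound 3 to compound 4 (beyond the scatter). Compound 4 is accordingly expected to give 50%, in a range from 32% to 68%.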

Compound 4, percent growth inhibition at one concentration: 50%
Compound 4: the middle estimate sits on the measured number at the digits printed; the measured number falls inside the stated range.
By their numbers in this assay, from the lowest: compounds 2, 1 and 4 (each within the scatter of the next); then compound 3.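

In this assay the iodo group, a single heavy atom with no hydrogen-bond donors or acceptors and the only halogen among these compounds, gives a number 18 percentage points lower from compound 3 to compound 4 (beyond the scatter) and so joins nitro and methoxy in giving a lower number than hydrogen on this aromatic carbon. The three substituents do not separate from one another, since the readings of a number 9 percentage points higher from compound 2 to compound 4 (within the scatter) and a number 5 percentage points higher from compound 1 to compound 4 (within the scatter) both lie within the scatter, which leaves compound 3 alone above a group of three despite the differences between those substituents. No measured evidence here explains why hydrogen on this carbon goes with more growth inhibition than any of the three substituents.

From the compounds shown here alone, whether the same drop would follow with a smaller halogen such as fluoro, or with an amine or a carboxylic acid on this carbon, remains open, as does whether any group there could match or exceed compound 3 in this assay at all. Also open, going by these compounds, is how these substituents would behave with a longer chain in the molecule, since all four compounds share the same chain.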